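Swapping methoxymethyl for hydrogen on compound 1

A few compounds are considered here, and "the series" means these few. Any claim that something is new, unique, unknown or untested is made for them only; others in the source may bear on it.

Within the data shown here, in a functional assay on MCF7 cells (Homo sapiens) for antiproliferative activity, read by MTT assay (on this read-out lower numbers stand for stronger inhibition and higher numbers for weaker inhibition), compound 1 (`CC/C=C\C/C=C\C/C=C\CCCCCCCC1(O)CC(=O)c2c(O)cc(OCOC)cc2O1`) gives 17500 nM as the only true number so far. Compound 2 (`CCCCC/C=C\C/C=C\CCCCCCCC1(O)CC(=O)c2c(O)cc(OCOC)cc2O1`) is reported as a limit only (> 84100 nM). Among the measured compounds shown here, the one measured step (an at least 4.8-fold higher number from compound 1 to compound 2 (0.68 log units; beyond the scatter)) puts butyl in place of but-1-en-1-yl on a saturated chain carbon and leaves the methoxymethoxy group untouched. Compound 3 (`CC/C=C\C/C=C\C/C=C\CCCCCCCC1(O)CC(=O)c2c(O)cc(O)cc2O1`) keeps the chain of compound 1 and differs elsewhere (hydrogen in place of methoxymethyl on an oxygen on an aromatic ring): hydrogen in place of methoxymethyl on an oxygen on an aromatic ring, or methoxymethoxy to hydroxy. For the measured compounds named here, the chain step says nothing direct about this oxygen, and no measured pair isolates the change. With compound 1 at 17500 nM as the only anchor, no step beyond the scatter is expected in this assay in either direction, though the uncertainty is wide. The expected change is small (a 1.2-fold lower number from compound 1 to compound 3 (0.07 log units; within the scatter)). Compound 3 is estimated at 15000 nM (estimated range 5000 nM to 50000 nM).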

Compound 3, half-maximal inhibitory concentration: 17500 nM
Beside the measured number, compound 3's estimate is 1.2-fold (0.07 log units) below it, and the stated range covers the measured number.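

In this assay, among these compounds, the earlier compounds showed a step in the chain only, with the methoxymethoxy group in place, and so said nothing about this oxygen. The new pair isolates that oxygen: hydrogen in place of methoxymethyl on an oxygen on an aromatic ring gives no change at the digits printed from compound 1 to compound 3 (within the scatter). With the chain of compound 1, methoxymethoxy and hydroxy are therefore not told apart by this read-out, and the only step shown beyond the scatter remains the one in the chain.

Going by these compounds, whether a methyl ether or an acetyl ester on this oxygen would also leave the number in place stays open. Compound 2 is a limit of the assay, and whether the same change would count on its chain also stays open: the limit of > 84100 nM in this assay, at which 1 of the 3 values shown sits.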